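Ring Fluorination in a Dopamine Receptor Ligand Series

The source may hold more compounds than are shown below. What is called first, only, known or untested is meant among the compounds shown, and "the series" means these compounds.

Compound 1 `COc1ccccc1N1CCN(CCCNC(=O)NN(Cc2ccccc2)c2ccc(Cl)cc2)CC1`: 2.9 nM
Compound 2 `COc1ccccc1N1CCN(CCCNC(=O)NN(Cc2ccccc2F)c2ccc(Cl)cc2)CC1`: 2.6 nM
Compound 3 `COc1ccc(N(Cc2ccccc2)NC(=O)NCCCN2CCN(c3ccccc3OC)CC2)cc1`: 1.7 nM

Three compounds were measured in an assay on CHO cells for displacement of a labelled ligand from D(4) dopamine receptor (Homo sapiens), read by radioligand binding; on this read-out lower numbers stand for stronger inhibition and higher numbers for weaker inhibition. Compound 1 gives 2.9 nM in this assay, and compound 2 gives 2.6 nM; the change between them is fluoro in place of hydrogen on an aromatic carbon, with a step of a 1.1-fold lower number from compound 1 to compound 2 (0.05 log units; within the scatter). Compound 3 gives 1.7 nM; its core differs from that of compound 1 by methoxy in place of chloro on an aromatic carbon, a step of a 1.7-fold lower number from compound 1 to compound 3 (0.23 log units; within the scatter). All three values lie within the usual scatter of one another.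

Compound 4 `COc1ccc(N(Cc2ccccc2F)NC(=O)NCCCN2CCN(c3ccccc3OC)CC2)cc1` has not yet been measured. It differs from compound 3 by fluoro in place of hydrogen on an aromatic carbon, which is the same change as that from compound 1 to compound 2. Because that earlier step was a 1.1-fold lower number from compound 1 to compound 2 (0.05 log units; within the scatter), a step of similar size, a 1.1-fold lower number from compound 3 to compound 4 (0.05 log units; within the scatter), is expected from compound 3 to compound 4 in this assay. Compound 4 is therefore estimated at 1.5 nM, with a likely range of 0.6 nM to 4 nM.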

Compound 4, inhibition constant: 2.6 nM
Estimate against measurement, compound 4: 1.7-fold (0.24 log units) below, and the stated range covers the measured number.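

In this assay, fluoro in place of hydrogen gave a 1.5-fold higher number from compound 3 to compound 4 (0.18 log units; within the scatter), and the change reads alike on the two cores: the same change on two cores in this assay, a 1.1-fold lower number (0.05 log units; within the scatter) from compound 1 to compound 2 and a 1.5-fold higher number (0.18 log units; within the scatter) from compound 3 to compound 4, 1.7-fold (0.23 log units) apart, within the scatter of two such steps. Methoxy in place of chloro gave no change at the digits printed from compound 2 to compound 4 (within the scatter), and this change also reads alike on the two cores: the same change on two cores in this assay, a 1.7-fold lower number (0.23 log units; within the scatter) from compound 1 to compound 3 and no change at the digits printed (within the scatter) from compound 2 to compound 4, 1.7-fold (0.23 log units) apart, within the scatter of two such steps. All of these steps lie within the scatter, so the pairs show no disagreement between the cores, but they do not show that either change has a real effect or that it would carry to further cores.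

The compounds shown leave open how a bromo or methyl group in place of the fluoro of the 2-fluorobenzyl group would read. They also leave open how a nitrile or trifluoromethyl group in place of the methoxy or chloro would read.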